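This account rests on a few compounds, and the source may have more. Where it says the series, first, only, none or still open, it means among the compounds named here.

Compound 1 `CCCOC1=C(CCC)C(=O)/C(=C(O)/C=C/c2ccccc2)C(=O)C1(CCC)CCC`: 1.6 uM
Compound 2 `CCCC1(CC=C(C)C)C(=O)C(C(=O)/C=C/c2ccccc2)=C(O)C(CCC)(CCC)C1=O`: 5.8 uM
Compound 3 `CCCOC1=C(CCC)C(=O)/C(=C(O)/C=C/c2ccc(I)cc2)C(=O)C1(CCC)CCC`: 5.1 uM

These three compounds were tested in a functional assay on MCF7 cells (Homo sapiens) for antiproliferative activity, read by sulforhodamine B assay, with a stated time of 3 days; on this read-out lower numbers stand for an effect already at smaller amounts and higher numbers for an effect only at larger amounts of compound. Among them compound 1 gives the lowest number; compound 3 comes nearest, and compound 2 is furthest away. Compound 4 `CCCC1=C(OCCC(C)C)C(CCC)(CCC)C(=O)/C(=C(O)\C=C\c2ccccc2)C1=O` differs from compound 1 by isopropyl in place of methyl on a saturated chain carbon, two bonds along the chain from an oxygen on an unsaturated carbon. Going by the values given here, the one measured step, a 3.2-fold higher number from compound 1 to compound 3 (0.50 log units; beyond the scatter), changes the aromatic ring and leaves this chain untouched, so it says nothing about the present change. Compound 1 and compound 2 differ in more than one place, so compound 2 at 5.8 uM offers no guide either. Among the compounds with values here, with no measured step bearing on this change, compound 4 is expected to stay close to compound 1, an estimated step of a 1.3-fold higher number from compound 1 to compound 4 (0.10 log units; within the scatter) within the scatter. The estimated value for compound 4 is 2 uM, with a range from 0.8 uM to 5 uM.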

Compound 4, concentration for half-maximal effect: 9.1 uM
Compound 4: the middle estimate sits 4.6-fold (0.66 log units) below what was measured; measured number outside the range, above it.
By their numbers in this assay, from the lowest: compound 1; then compounds 3, 2 and 4 (each within the scatter of the next).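

Going from propoxy to isopentyloxy on the shared core gives a 5.7-fold higher number from compound 1 to compound 4 (0.75 log units; beyond the scatter) in this assay. Until now, the only single change shown was on the aromatic ring; this step shows that the number also responds to a change at the end of this oxygen-bound chain, with isopropyl in place of methyl raising it beyond the scatter. No available evidence accounts for this rise.

Going by these compounds, it remains open whether a straight pentyloxy chain would give a similar rise, or whether a shorter ethoxy chain would change the number at all. A chain ending in an amine or a carboxylic acid is also untested among these compounds.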